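The compounds below may be only part of what the source reports. "The series", "measured", "known", "first", "only" and "open" are said of these compounds alone.

Compound 1, `COc1ccccc1S(=O)(=O)c1ccc(NC(=O)C(C)(O)C(F)(F)F)cc1`: 1600 nM
Compound 2, `CC(O)(C(=O)Nc1ccc(C(=O)c2cccc(F)c2)cc1)C(F)(F)F`: 2600 nM

Both were tested in a functional assay (Cavia porcellus) with sulfonylurea receptors; K-ATP channels (Homo sapiens) as the target; on this read-out higher numbers stand for weaker inhibition and lower numbers for stronger inhibition. Compound 1 gives the lower of the two numbers, but its gap to compound 2 lies within the scatter, so the two cannot be told apart. Compound 3, `CC(O)(C(=O)Nc1ccc(S(=O)(=O)c2nccs2)cc1)C(F)(F)F`, is not yet measured. It differs from compound 1 in one place: 1,3-thiazol-2-yl in place of 2-methoxyphenyl on a sulfonyl sulfur. Among the compounds with values here, no measured pair shows this change, so there is no step to lean on. The number is expected to stay near that of compound 1, a step of a 1.3-fold higher number from compound 1 to compound 3 (0.10 log units; within the scatter), not beyond the scatter. Compound 3 is expected at 2000 nM, within 600 nM to 7000 nM.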

Compound 3, half-maximal inhibitory concentration: 1400 nM
For compound 3 the middle estimate is 1.4-fold (0.15 log units) above the measured one; low and high end bracket the measured number.
By their numbers in this assay, from the lowest: compounds 3, 1 and 2 (each within the scatter of the next).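

Putting 1,3-thiazol-2-yl in place of 2-methoxyphenyl on the sulfonyl sulfur gives a 1.1-fold lower number from compound 1 to compound 3 (0.06 log units; within the scatter) and so, in this assay, compound 1 and compound 3 cannot be told apart. This position therefore accepts a five-membered aromatic ring with 2 hetero atoms as well as a six-membered carbon ring, with 5 heavy atoms instead of 8. No measurement at hand offers a reason for this. Open, from the compounds shown here alone, is whether an aromatic ring is needed here at all: a simple methyl group, a longer alkyl chain or an amine on the sulfonyl sulfur could answer that.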